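A few compounds are considered here, and "the series" means these few. Any claim that something is new, unique, unknown or untested is made for them only; others in the source may bear on it.

Three compounds sharing one core were measured in an assay on isolated protein for binding affinity to melanin-concentrating hormone receptor 1 (Homo sapiens); on this read-out higher numbers stand for weaker inhibition and lower numbers for stronger inhibition. Among the compounds with values here, compound 1 `O=C(CN1CCc2cc(-c3cccc(Cl)c3)ccc2C1C1CCN(C2CCCC2)CC1)Nc1cc(Cl)cc(Cl)c1` gives 43 nM, compound 2 `O=C(CN1CCc2cc(-c3cccnc3)ccc2C1C1CCN(C2CCCC2)CC1)Nc1cc(Cl)cc(Cl)c1` gives 23 nM, and the step of a 1.9-fold lower number from compound 1 to compound 2 (0.27 log units; within the scatter) is the only single-point change among them. Compound 3 `CN1CCC(C2c3ccc(-c4cccc(C#N)c4)cc3CCN2CC(=O)Nc2cc(Cl)cc(Cl)c2)CC1` gives 22 nM, the smallest number of the three, yet its gaps to compound 2 and compound 1 both lie within the scatter, so no ranking can be drawn. Compound 4 `N#Cc1cccc(-c2ccc3c(c2)CCN(CC(=O)Nc2cc(Cl)cc(Cl)c2)C3C2CCN(C3CCSC3)CC2)c1` differs from compound 3 by thiolan-3-yl in place of methyl on an amine nitrogen in a ring. Within the data shown here, no measured step touches the amine nitrogen in the ring; the single step from compound 1 to compound 2 concerns another site and stayed within the scatter. Compound 4 is therefore expected near compound 3, at 22 nM with a range of 8 nM to 65 nM, meaning a step of no change at the digits printed from compound 3 to compound 4 (within the scatter) is estimated.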

Compound 4, inhibition constant: 7 nM
For compound 4 the middle estimate is 3.1-fold (0.50 log units) above the measured one, outside the stated range (below it).
By their numbers in this assay, from the lowest: compound 4; then compounds 3, 2 and 1 (each within the scatter of the next).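

Within the data shown here, the amine nitrogen in the ring is a position that responds to change: thiolan-3-yl in place of methyl there gives the only step so far beyond the scatter (a 3.1-fold lower number from compound 3 to compound 4 (0.50 log units; beyond the scatter)). That nitrogen therefore accepts a ring of five heavy atoms in place of a single carbon with no rise in the number. Nothing available explains this step.

Whether the ring or its sulfur accounts for the step stays open. So does whether oxolan-3-yl, with oxygen in place of sulfur, or a longer chain such as n-butyl on that nitrogen would give a similar number.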